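The compounds below may be only part of what the source reports. "The series", "measured", "known", "first", "only" and "open" are said of these compounds alone.

Compound 1 `C#CCNC(=O)/C(C)=C(\C)c1ccc(OC)cc1` was tested in a toxicity assay on the whole organism (strain Icem-CET (SPF Caw)) for cytotoxicity, with Mus musculus as the target (a lower number here means that less compound is needed, a higher number that more compound is needed for the effect), where compound 1 gives 150 mg/kg. Its only measured companion, compound 2 `C=CCNC(=O)/C(C)=C(\C)c1ccc(OC)cc1`, gives 300 mg/kg in this assay, and the step of a 2.0-fold higher number from compound 1 to compound 2 (0.30 log units; within the scatter) concerns the chain end only. Compound 3 `C#CCNC(=O)/C(C)=C(\C)c1ccccc1` differs from compound 1 at another place: hydrogen in place of methoxy on an aromatic carbon. Within the data shown here, no measured step touches the methoxy, so nothing here bears directly on this change, and the one step that was measured stayed within the scatter. The expected step is therefore no change at the digits printed from compound 1 to compound 3 (within the scatter), nothing beyond the scatter. Compound 3 is estimated at 150 mg/kg, with a range from 75 mg/kg to 300 mg/kg.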

Compound 3, dose for half-maximal effect: 150 mg/kg
For compound 3 middle estimate and measured number coincide at the digits printed, within the range that was stated.
By their numbers in this assay, from the lowest: compounds 1, 3 and 2 (each within the scatter of the next).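

Removing the methoxy from the aromatic carbon of the ring, leaving hydrogen there, gives no change at the digits printed from compound 1 to compound 3 (within the scatter) in this assay. Among these compounds, the earlier compounds changed only the chain end, so this is the first reading at the ring position, and the dose stays within the scatter with or without the methoxy. A single replacement cannot show whether other groups there would behave alike.

Going by these compounds, it remains open whether a larger or charged group at this carbon, such as an amine or a carboxylic acid, would shift the number, and no available measurement explains the present result.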